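Stability notes on a stereocentre flip in the series

The source may report more compounds than this note shows. Statements on the series, on what has been measured and on what is new or still open speak of the compounds shown alone.

compound 1 `CC(C)[C@@H](C[C@H]1SC(=O)NC1=O)c1ccc(-c2ccc3cccc(F)c3c2)[nH]c1=O`: 1.24 h in an ADME assay on microsomes from liver (Homo sapiens) for metabolic stability; on this read-out lower numbers stand for a shorter-lived compound and higher numbers for a longer-lived compound
compound 2 `CC(C)C(/C=C1\OC(=O)NC1=O)c1cc(Cl)c(-c2ccc3cccc(F)c3c2)[nH]c1=O`: > 3 h, a limit
compound 3 `CC(C)C(/C=C1\NC(=O)NC1=O)c1ccc(-c2ccc3cccc(F)c3c2)[nH]c1=O`: > 3 h, a limit

Among the measured compounds shown here, compound 1 carries the only actual number in this assay; the other two results are limits, not numbers, as the limit of > 3 h in this assay, at which 2 of the 3 values shown sit, records. Compound 4 `CC(C)[C@H](C[C@H]1SC(=O)NC1=O)c1ccc(-c2ccc3cccc(F)c3c2)[nH]c1=O` is the partner of compound 1: the two compounds have the same atoms and bonds and differ only in configuration as drawn: 1 of 2 stereo elements differ; a stereocentre at a saturated chain carbon is drawn R in compound 1 and S in compound 4. For the measured compounds named here, no measured step of this sort exists in the set, so no direction can be read off; the expected step is small and within the scatter, in either sense. Compound 4 is therefore expected near 1.3 h, with a range from 0.6 h to 2.8 h. That expectation amounts to the step of a 1.0-fold higher number from compound 1 to compound 4 (0.02 log units; within the scatter), with the remaining chance that this assay returns only a limit for compound 4.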

Compound 4, half-life: 0.67 h
Compound 4: middle estimate off by 1.9-fold (0.29 log units), on the high side, within the range that was stated.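

In this assay, inverting the stereocentre at the saturated chain carbon gives a 1.9-fold lower number from compound 1 to compound 4 (0.27 log units; within the scatter). Among the compounds shown here, this is the first measured step at this position, and it isolates the stereocentre, with no other structural change involved: the fact that compounds 1 and 4 differ only in the configuration as drawn On this pair, the configuration at this carbon gives no separation beyond the scatter.

For the compounds shown here, compounds 2 and 3 give only limits and add no comparison to this pair: the limit of > 3 h in this assay, at which 2 of the 4 values shown sit. Whether the two configurations would stay as close with an amine or a longer chain at this carbon remains open.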